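Swapping the aryl ring on a fused oxygen-containing core

The compounds below may be only part of what the source reports. "The series", "measured", "known", "first", "only" and "open" are said of these compounds alone.

Of the compounds shown here, two sharing one core have been tested so far, and both differ only in the aromatic ring attached to the core. Compound 1, `CCC1=C(O)c2c(oc(-c3ccc(OC)cc3)cc2=O)C(CC)(CC)C1=O`, carries a 4-methoxyphenyl group; in a functional assay on KBVIN cells (Homo sapiens) for antiproliferative activity, read by sulforhodamine B assay, with a stated time of 3 days (a higher number here means that more compound is needed for the effect, a lower number that less compound is needed), compound 1 gives 0.68 uM. Compound 2, `CCC1=C(O)c2c(oc(-c3cccc(OC(F)(F)F)c3)cc2=O)C(CC)(CC)C1=O`, carries a 3-(trifluoromethoxy)phenyl group instead; in this assay compound 2 gives 9.95 uM. Of these two numbers, compound 1 has the lower one, and the gap to compound 2 lies beyond the usual scatter of the measurement.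

The next compound, compound 3, `CCC1=C(O)c2c(oc(-c3ccc(C)c(F)c3)cc2=O)C(CC)(CC)C1=O`, keeps the core and again replaces the aromatic ring: 3-fluoro-4-methylphenyl in place of 4-methoxyphenyl on an aromatic carbon. The ring that enters has no hydrogen-bond acceptor where the leaving ring had one. Only two data points exist, so the expectation rests on them alone. A weakening is expected, though probably a smaller one than the gap between compound 1 and compound 2, because compound 2 gives 9.95 uM with a ring quite different from either. The expected step is a 3.7-fold higher number from compound 1 to compound 3 (0.57 log units; beyond the scatter). Compound 3 is therefore estimated to give 2.5 uM in this assay, within a range from 0.8 uM to 8 uM.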

Compound 3, concentration for half-maximal effect: 2.95 uM
Estimate against measurement, compound 3: 1.2-fold (0.07 log units) below, and the stated range covers the measured number.
By their numbers in this assay, from the lowest: compound 1; then compound 3; then compound 2.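

The step at this position is real: replacing 4-methoxyphenyl with 3-fluoro-4-methylphenyl gives a 4.3-fold higher number from compound 1 to compound 3 (0.64 log units; beyond the scatter), so in this assay the aromatic ring on the shared core can change the reading even when the entering and leaving rings have the same number of heavy atoms. Compound 3, at 2.95 uM, also falls between compound 1 and compound 2 in the printed values, which shows that a ring with no hydrogen-bond acceptor can still give a lower number than the 3-(trifluoromethoxy)phenyl ring of compound 2. No measurement here explains the step, so the reason for it remains unknown.

This single swap removes the methoxy group and adds both a fluorine and a methyl group, so the shift cannot be assigned to any one of these changes. Still open, from the compounds shown here alone, is how the reading would move with a ring carrying only the methyl group or only the fluorine, with an unsubstituted phenyl ring, or with a ring bearing an amine.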